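The source may report more compounds than this note shows. Statements on the series, on what has been measured and on what is new or still open speak of the compounds shown alone.

In an ADME assay on BJ cells (Homo sapiens) for cytotoxicity, with a stated time of 72 h (on this read-out higher numbers stand for an effect only at larger amounts of compound and lower numbers for an effect already at smaller amounts), compound 1 (`CSc1ccc(NC(=O)Nc2cc(C)nc3ccccc23)cc1`) gives > 25000 nM as a limit, not a number. Compound 2 (`Cc1cc(NC(=O)Nc2cccc([N+](=O)[O-])c2)c2ccccc2n1`) likewise gives > 25000 nM as a limit. The measurements so far thus amount to the limit of > 25000 nM in this assay, at which 2 of the 2 values shown sit, and offer no number. Compound 3 (`COC(=O)c1ccc(NC(=O)Nc2cc(C)nc3ccccc23)cc1`) carries one change from compound 1 (methoxycarbonyl in place of methylsulfanyl on an aromatic carbon), with methoxycarbonyl in place of methylsulfanyl on an aromatic carbon, para to a large group. With compound 1 at > 25000 nM as a limit, no step beyond the scatter is expected in this assay in either direction. The expected step (a step that the limit leaves unreadable from compound 1 to compound 3) is only an estimate. For compound 3 the estimated value is 30000 nM with an expected range of 12000 nM to 60000 nM for now.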

Compound 3, half-maximal effective concentration: 21000 nM
Beside the measured number, compound 3's estimate is 1.4-fold (0.15 log units) above it; the range from low to high includes it.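

With methoxycarbonyl in place of methylsulfanyl on an aromatic carbon, para to a large group, this assay shows an at least 1.1-fold lower number from compound 1 to compound 3 (0.07 log units; that floor lies within the scatter) and no more than that floor can be read. Among the compounds shown here, this change at this position gives the first value that is a number rather than a limit, and the floor shows no shift beyond the scatter. The other values remain limits: the limit of > 25000 nM in this assay, at which 2 of the 3 values shown sit. Going by these compounds, the true size of the step stays open, for compound 1 offers no number. Also open, on these data alone, is how an amine or a carboxylic acid at this position would read in this assay.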